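The (1-bromoethenyl)carbonyl-to-hydrogen change on two cores

A few compounds are considered here, and "the series" means these few. Any claim that something is new, unique, unknown or untested is made for them only; others in the source may bear on it.

Compound 1 `C=C(Br)C(=O)Nc1ccc(/C=C/C(=O)c2ccc(OCC)cc2)cc1` and compound 3 `CCOc1ccc(C(=O)/C=C/c2ccc(N)cc2)cc1` share one core; compound 3 carries hydrogen in place of (1-bromoethenyl)carbonyl on a nitrogen on an aromatic ring. In an ADME assay on CCRF-CEM cells (Homo sapiens) for antiproliferative activity, with a stated time of 48 h (on this read-out lower numbers stand for stronger inhibition and higher numbers for weaker inhibition), compound 1 gives 750 nM and compound 3 gives 15000 nM, a step of a 20-fold higher number from compound 1 to compound 3 (1.30 log units; beyond the scatter). Compound 2 `C=C(Br)C(=O)Nc1ccc(C(=O)/C=C/c2ccccc2)cc1` rests on a different core; how the two cores differ is not broken down here. In this assay compound 2 gives 1500 nM. Compound 4 `Nc1ccc(C(=O)/C=C/c2ccccc2)cc1` is not yet measured; relative to compound 2 it carries hydrogen in place of (1-bromoethenyl)carbonyl on a nitrogen on an aromatic ring, the same change at the same place as from compound 1 to compound 3. With a single earlier instance of this change, the expected step for compound 4 is a 20-fold higher number from compound 2 to compound 4 (1.30 log units; beyond the scatter), resting on the measured step of a 20-fold higher number from compound 1 to compound 3 (1.30 log units; beyond the scatter). Compound 4 is therefore estimated at 30000 nM, with a likely range from 10000 nM to 90000 nM.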

Compound 4, half-maximal inhibitory concentration: 8500 nM
Compound 4: the middle estimate sits 3.5-fold (0.55 log units) above what was measured; the whole stated range lies above it.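

Taking the (1-bromoethenyl)carbonyl group off the nitrogen raises the number on the second core as well in this assay, a 5.7-fold higher number from compound 2 to compound 4 (0.75 log units; beyond the scatter), so the direction of the change holds for both pairs. The size of the step does not carry over from one core to the other: the same change on two cores in this assay, a 20-fold higher number (1.30 log units; beyond the scatter) from compound 1 to compound 3 and a 5.7-fold higher number (0.75 log units; beyond the scatter) from compound 2 to compound 4, 3.5-fold (0.55 log units) apart, beyond the scatter of two such steps

These two pairs give no general size for this change, and they do not show which feature of the two cores goes with the difference in step size. The compounds shown leave open how much of either step belongs to the bromine and how much to the rest of the group, a question that an acetyl or unsubstituted acryloyl group on the same nitrogen would address.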